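Cytotoxicity notes: methoxyphenyl to chlorophenyl exchange

This account rests on a few compounds, and the source may have more. Where it says the series, first, only, none or still open, it means among the compounds named here.

Measured so far:
compound 1 `COc1ccc(N2CCN(CC(=O)N3CCN(c4nnc(-c5ccccc5)c(-c5ccccc5)n4)CC3)CC2)cc1` — > 910000 nM, a limit
compound 2 `COc1ccc(-c2nnc(N3CCN(C(=O)CN4CCN(c5ccccc5OC)CC4)CC3)nc2-c2ccc(OC)cc2)cc1` — > 821000 nM, a limit
compound 3 `COc1ccc(-c2nnc(N3CCN(C(=O)CN4CCN(c5cccc(OC)c5)CC4)CC3)nc2-c2ccc(OC)cc2)cc1` — > 821000 nM, a limit

In an ADME assay on NIH3T3 cells (Mus musculus) for cytotoxicity, read by MTT assay, with a stated time of 24 h (on this read-out higher numbers stand for weaker inhibition and lower numbers for stronger inhibition), compound 1 gives only a limit, > 910000 nM. In this assay compound 2 likewise gives a limit, > 821000 nM. Compound 3 also gives a limit, > 821000 nM, so no number places it relative to the others. Among the measured compounds shown here, the sole measured step, a step that the two limits leave unreadable from compound 2 to compound 3, is unreadable because the limit of > 821000 nM in this assay, at which 2 of the 3 values shown sit, caps both ends.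

Compound 4 `COc1ccc(-c2nnc(N3CCN(C(=O)CN4CCN(c5ccc(Cl)cc5)CC4)CC3)nc2-c2ccc(OC)cc2)cc1` differs from compound 3 by 4-chlorophenyl in place of 3-methoxyphenyl on an amine nitrogen in a ring. For the measured compounds named here, no measured step carries this change, and the one step on record gives no size. Compound 4 is therefore expected to remain at the limit, with an estimated step of a number no higher from compound 3 to compound 4 (the limit leaves the size open) of no readable size. The estimate for compound 4 is 821000 nM, range 300000 nM to 2000000 nM, most likely reported again as a limit.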

Compound 4, half-maximal inhibitory concentration: > 814000 nM
Compound 4 was reported as a limit; the forecaster's own chance of this, stated with the estimate: 90%; the middle value is on the limit's open side.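

In this assay compound 4 gives > 814000 nM, a limit, and the steps to it from compound 2 and compound 3 cannot be read. The compounds shown leave open whether 4-chlorophenyl in place of either methoxyphenyl changes cytotoxicity at all.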